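The compounds below may be only part of what the source reports. "The series", "measured", "known", "first", "only" and "open" are said of these compounds alone.

Among the measured compounds shown here, compound 2 `N#Cc1cccc(/C=C2\Cc3cc(O)ccc3C2=O)c1` is one of only two compounds measured so far in an assay on isolated protein for inhibition of Amine oxidase [flavin-containing] A (Homo sapiens), read by fluorescence and spectrophotometry, with a stated time of 20 min; a lower number here means a stronger inhibitor, a higher number a weaker inhibitor. In this assay compound 2 gives 444 nM, the higher of the two numbers, while compound 1 `O=C1/C(=C/c2cccc(Cl)c2)Cc2cc(O)ccc21` gives 157 nM. For the measured compounds named here, the single measured step, a 2.8-fold higher number from compound 1 to compound 2 (0.45 log units; beyond the scatter), accompanied the exchange of cyano in place of chloro on an aromatic carbon. Compound 3 `COc1cccc(/C=C2\Cc3cc(O)ccc3C2=O)c1` differs from compound 2 at that same aromatic carbon: methoxy in place of cyano on an aromatic carbon. Going by the values given here, no measured step exchanges cyano for methoxy, so the only guide is that changing the group on this aromatic carbon once moved the number modestly. A step of similar size is therefore expected, and a drift back toward compound 1 is thought a little more likely than a further rise because compound 1 gives 157 nM with chloro there, so the estimated step is a 1.8-fold lower number from compound 2 to compound 3 (0.25 log units; within the scatter). Compound 3 is accordingly expected to give about 250 nM, within roughly 100 nM to 700 nM.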

Compound 3, half-maximal inhibitory concentration: 1190 nM
The estimate for compound 3 lay 4.8-fold (0.68 log units) below the measured number, and the stated range ends below it.
By their numbers in this assay, from the lowest: compound 1; then compound 2; then compound 3.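

In this assay this aromatic carbon now carries three different groups across the compounds, and methoxy gives the weakest inhibitor of the three: the change from cyano is a 2.7-fold higher number from compound 2 to compound 3 (0.43 log units; beyond the scatter) and the change from chloro is a 7.6-fold higher number from compound 1 to compound 3 (0.88 log units; beyond the scatter) in the same direction. Cyano and methoxy have the same counts of heavy atoms and hydrogen-bond acceptors and no net charge, yet their numbers still differ beyond the scatter, so these counts alone do not set the number at this position. No measurement shown here explains why these groups differ.

As far as these compounds go, it remains open where other groups on this carbon, such as an amine, a carboxylic acid or a longer chain, would fall relative to these three. From the compounds shown here alone, it is also open whether the same order would hold with these groups on another carbon of this aromatic ring.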